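A few compounds are considered here, and "the series" means these few. Any claim that something is new, unique, unknown or untested is made for them only; others in the source may bear on it.

Measured in a functional assay on DU-145 cells (Homo sapiens) for inhibition, read by trypan blue exclusion, with a stated time of 96 h; a higher number here means a weaker inhibitor of growth, a lower number a stronger inhibitor of growth:
- compound 1 `COc1cc(OC)c(/C=C(/Sc2ccc(C)cc2)C(=O)c2ccc(Cl)cc2)c(OC)c1`: > 100000 nM (a limit)
- compound 2 `COc1cc(OC)c(/C=C(/Sc2ccc(C)cc2)C(=O)c2ccc(Br)cc2)c(OC)c1`: > 100000 nM (a limit)
- compound 3 `O=C(O)c1ccc(C(=O)/C(=C\c2ccc(F)c([N+](=O)[O-])c2)SCc2ccc(Cl)cc2)cc1`: 50000 nM

Compound 1 gives only a limit, > 100000 nM, and no number. Most of the series stands there: the limit of > 100000 nM in this assay, at which 2 of the 3 values shown sit.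

Compound 4 `COc1cc(OC)c(/C=C(\C(=O)c2ccc(Cl)cc2)S(=O)(=O)c2ccc(C)cc2)c(OC)c1` carries (4-methylphenyl)sulfonyl in place of (4-methylphenyl)sulfanyl on a double-bonded chain carbon bound to a carbonyl carbon and a double-bonded chain carbon, with (4-methylphenyl)sulfonyl in place of (4-methylphenyl)sulfanyl on a double-bonded chain carbon bound to a carbonyl carbon and a double-bonded chain carbon.

Within the data shown here, the one measured step, a step that the two limits leave unreadable from compound 1 to compound 2, concerns another place and gives no size to carry over. Among the measured compounds shown here, the expectation therefore leans on compound 3, which gives 50000 nM, the only number. A modest move toward stronger inhibition is expected, as the estimated step of an at least 2.0-fold lower number from compound 1 to compound 4 (0.30 log units; that floor lies within the scatter). The estimate for compound 4 is 50000 nM, with an expected range of 5000 nM to 150000 nM.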

Compound 4, concentration for 50% growth inhibition: 25000 nM
Estimate against measurement, compound 4: 2.0-fold (0.30 log units) above, within the range that was stated.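

Replacing (4-methylphenyl)sulfanyl with (4-methylphenyl)sulfonyl on this double-bonded chain carbon gives, in this assay, an at least 4.0-fold lower number from compound 1 to compound 4 (0.60 log units; beyond the scatter). Compound 4 thus gives the first number among the compounds shown with a 4-methylphenyl group at this position, so the position responds to a change in the sulfur group. Compound 1 and compound 2, both sulfanyl compounds, remain at a limit of the assay: the limit of > 100000 nM in this assay, at which 2 of the 4 values shown sit.

As far as these compounds go, whether the same change holds with bromo in place of chloro remains open. From the compounds shown here alone, how a sulfinyl group or a sulfonamide at this position would read also remains open.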